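The source may hold more compounds than are shown below. What is called first, only, known or untested is meant among the compounds shown, and "the series" means these compounds.

Going by the values given here, compound 2 `COC(=O)/C=C/NC(=O)[C@@H](O)C(C)(C)CO` is the only member of this small set with a number: in an ADME assay on WI-38 cells (Homo sapiens) for inhibition, read by CellTiter-Glo, with a stated time of 48 h, tested at 100 uM (a lower number here means less inhibition, a higher number more inhibition at the concentration tested (going by the name of the read-out)), compound 2 gives -18%. Compound 1 `COC(=O)/C=C\NC(=O)[C@H](O)C(C)(C)CO` is set apart from it by the fact that compounds 1 and 2 differ only in the configuration as drawn, and in this assay compound 1 gives "not determined" (no result reported). Compound 3 `CCOC(=O)/C=C/NC(=O)[C@@H](O)C(C)(C)CO` carries methyl in place of hydrogen on a saturated chain carbon bound to an oxygen next to a carbonyl group relative to compound 2. Among the compounds with values here, no step between measured compounds is available to set a scale, yet a change this small is expected to move this assay by nothing beyond the scatter, so the step of a number 8 percentage points higher from compound 2 to compound 3 (within the scatter) is expected to be slight. Compound 3 is therefore estimated at -10%, between -35% and 20%.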

Compound 3, a percentage reported as inhibition, at one concentration (the size of the read-out at that concentration, not a potency): -6%
The estimate for compound 3 lay 4 percentage points below the measured number; the measured number falls inside the stated range.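

In this assay, going by these compounds alone, the change from methoxycarbonyl to ethoxycarbonyl gives a number 12 percentage points higher from compound 2 to compound 3 (beyond the scatter) and is the first step in this set that can be read. It shows that a single added methyl on a saturated chain carbon bound to an oxygen next to a carbonyl group is enough to register, although both compounds still read below zero. Nothing at hand accounts for this step. Going by these compounds, whether a longer chain such as propoxycarbonyl, or a carboxylic acid in place of the ester, would move the number further remains open. The compounds shown also leave open what the configuration as drawn contributes.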